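Methyl for Methoxy on Two Cores in One Assay

The source may hold more compounds than are shown below. What is called first, only, known or untested is meant among the compounds shown, and "the series" means these compounds.

Measured so far:
compound 1 `Cc1cc(C)cc(Sc2cccc(N)c2C#N)c1`: > 2000 nM
compound 2 `COc1cc(C)cc(Sc2cccc(N)c2C#N)c1`: 10000 nM
compound 3 `COc1ccccc1S(=O)(=O)c1cccc(N)c1C#N`: 146000 nM

Of the compounds shown here, three have been tested in a functional assay on MT4 cells (Homo sapiens) for cytotoxicity; a lower number here means a stronger inhibitor, a higher number a weaker inhibitor. For compound 1 the value is a limit of the assay, > 2000 nM. Compound 2 gives 10000 nM, and compound 3 gives 146000 nM, the highest number among the two that are numbers. From compound 2 to compound 1 the change is methyl in place of methoxy on an aromatic carbon, and the step is a step that the limit leaves unreadable from compound 2 to compound 1, because of the limit of > 2000 nM in this assay, at which 1 of the 3 values shown sits. How the core of compound 3 differs from that of compound 2 is not broken down here.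

Compound 4 `Cc1ccccc1S(=O)(=O)c1cccc(N)c1C#N` carries the same kind of change on the core of compound 3: methyl in place of methoxy on an aromatic carbon, here ortho to a large group rather than meta to a large group and meta to a methyl group. Since the measured step is unreadable, the expectation rests on compound 3 alone, at 146000 nM, and the step from compound 3 to compound 4 is estimated as a 1.2-fold lower number from compound 3 to compound 4 (0.09 log units; within the scatter). Compound 4 is therefore expected near 120000 nM, between 40000 nM and 400000 nM.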

Compound 4, half-maximal inhibitory concentration: > 200000 nM
Compound 4: no number, only a limit (the forecaster's own chance of this, stated with the estimate: 10%); at least 1.6-fold (0.22 log units) between middle value and limit.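

In this assay, methyl in place of methoxy on the core of compound 3 gives an at least 1.3-fold higher number from compound 3 to compound 4 (0.13 log units; that floor lies within the scatter). Compound 4 gives > 200000 nM, which is a limit of the assay and not a number. This shows the direction of the change on this one core but not its full size, and it does not show whether the change carries across cores, because the step from compound 2 to compound 1 cannot be read: the limit of > 2000 nM in this assay, at which 1 of the 4 values shown sits.

The compounds shown leave open how far compound 1 and compound 4 lie past their limits in this assay. They also leave open how an ethoxy group, an amine or a carboxylic acid in place of the methyl of compound 4 would read there.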